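The source may hold more compounds than are shown below. What is called first, only, known or untested is meant among the compounds shown, and "the series" means these compounds.

Measured in an ADME assay on HCT-116 cells (Homo sapiens) for cytotoxicity, read by CellTiter-Glo, with a stated time of 72 h; on this read-out lower numbers stand for stronger inhibition and higher numbers for weaker inhibition:
- Compound 1 `Cc1cc(C)c(S(=O)(=O)N2CCC(N3CCC(c4ccccc4)CC3)CC2)c(C)c1`: > 5000 nM
- Compound 2 `Cc1cc(C)c(S(=O)(=O)NCCN2CCC(C)CC2)c(C)c1`: > 5000 nM
- Compound 3 `Cc1cc(C)c(S(=O)(=O)N2CCC(N3CCCCCC3)CC2)c(C)c1`: > 5000 nM

Not yet measured:
- Compound 4 `Cc1cc(C)c(S(=O)(=O)N2CCC(N3CCC(CCC#N)CC3)CC2)c(C)c1`

In this assay, compound 1 gives > 5000 nM, which is a limit of the assay and not a number. It has company: the set so far shows (the limit of > 5000 nM in this assay, at which 3 of the 3 values shown sit). Within the data shown here, none of the three measured compounds therefore has an exact value, and no step between them can be sized.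

Compound 4 keeps the core of compound 1 and differs in one place, with 2-cyanoethyl in place of phenyl on a saturated ring carbon. This swaps an aromatic ring for a short open chain ending in a nitrile.

With no measured step to scale from, the data give no reason to expect a change in either direction. The expectation rests on compound 1, which reads > 5000 nM. The expected change is a step that the limit leaves unreadable from compound 1 to compound 4, a step no larger than the usual scatter. Compound 4 will most likely be reported as a limit again, with no exact number. For compound 4 the estimated value is 6000 nM. The expected range runs from 2500 nM to 15000 nM.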

Compound 4, half-maximal inhibitory concentration: > 5000 nM
Compound 4: no number, only a limit (the forecaster's own chance of this, stated with the estimate: 85%); the middle value lies beyond the limit too.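

In this assay compound 4 gives > 5000 nM, a limit of the assay and not a number. Among these compounds, compound 1 also carries only a limit, so no step between compound 1 and compound 4 can be read. The compounds shown leave open whether swapping phenyl for 2-cyanoethyl changes the value at all, since every reading is a limit: the limit of > 5000 nM in this assay, at which 4 of the 4 values shown sit.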